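One added methyl on a tightly bound compound

This account rests on a few compounds, and the source may have more. Where it says the series, first, only, none or still open, it means among the compounds named here.

Going by the values given here, in an ADME assay on a cell-free system (plasma, Mus musculus) for protein binding, compound 1 (`CNc1nccc(N2CC[C@H](NC(=O)Nc3ccc(Cl)c(C(F)(F)F)c3)C2)n1`) gives 99.8%, the lowest unbound fraction of the two compounds measured so far. Compound 2 (`CNc1nccc(N2CC[C@H](NC(=O)Nc3ccc(CN4CCC4)c(C(F)(F)F)c3)C2)n1`) gives 85.6%. Among the compounds with values here, the only measured step, a 72-fold higher unbound fraction from compound 1 to compound 2 (1.86 log units; beyond the scatter), is large and beyond the scatter, but it replaces chloro with (azetidin-1-yl)methyl, which is a different change from the one considered here. Compound 3 (`CCNc1nccc(N2CC[C@H](NC(=O)Nc3ccc(Cl)c(C(F)(F)F)c3)C2)n1`) keeps the chloro and differs from compound 1 by methyl in place of hydrogen on a saturated chain carbon bound to a nitrogen on an aromatic ring, turning methylamino into ethylamino. Within the data shown here, no measured step shows this change, so the large step offers no size to carry over. The expectation is therefore no step beyond the scatter in this assay. The estimated change is no change at the digits printed from compound 1 to compound 3 (within the scatter). For compound 3, the expected plasma protein binding is 99.8%, with a range of 99.5% to 99.95%.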

Compound 3, plasma protein binding: 99.9%
Compound 3: middle estimate off by 2.0-fold (0.30 log units) (unbound fraction), on the high side, and the stated range covers the measured number.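

In this assay, going by these compounds alone, turning methylamino into ethylamino gives a 2.0-fold lower unbound fraction from compound 1 to compound 3 (0.30 log units; within the scatter) and so offers the first reading at this place: methyl in place of hydrogen on a saturated chain carbon bound to a nitrogen on an aromatic ring leaves the result within the usual scatter. Of the two steps measured from compound 1, only a 72-fold higher unbound fraction from compound 1 to compound 2 (1.86 log units; beyond the scatter) lies beyond the scatter, so the clear rise in unbound fraction so far goes with (azetidin-1-yl)methyl in place of chloro and not with this added methyl. Nothing measured here explains either step.

A longer chain such as propyl, or a chain ending in a hydroxyl group or an amine, could still behave differently at this place. As far as these compounds go, it also remains open whether ethylamino would leave the result within the scatter alongside the (azetidin-1-yl)methyl group of compound 2.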